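The source may report more compounds than this note shows. Statements on the series, on what has been measured and on what is new or still open speak of the compounds shown alone.

Compound 3 `Nc1nc([SeH])nc2ccccc12` gives 80 nM in an ADME assay on BEAS-2B cells (Homo sapiens) for cytotoxicity, read by MTT assay, with a stated time of 72 h (a higher number here means a weaker inhibitor of growth, a lower number a stronger inhibitor of growth), the lowest of the two plain numbers shown there. Compound 1 `C[Se]c1nc(N)c2ccccc2n1` gives 23600 nM in this assay. Compound 2 `CCCCC[Se]c1nc([Se]CCCCC)c2ccccc2n1` gives > 100000 nM in this assay, and this is a limit of the assay rather than a number, namely (the limit of > 100000 nM in this assay, at which 1 of the 3 values shown sits).

The change from compound 3 to compound 4 `CCCCC[Se]c1nc(N)c2ccccc2n1` is pentyl in place of hydrogen on a selenium. Going by the values given here, only one measured step bears on this change: a 300-fold lower number from compound 1 to compound 3 (2.47 log units; beyond the scatter). That step shows that a bare hydrogen on the selenium of the shared core goes with a far lower number than a methyl on the same selenium. Compound 4 reverses that direction by putting pentyl, a longer alkyl group, in place of the hydrogen, so a large rise in the number is expected, at least of the size seen between compound 1 and compound 3. The expected step in this assay for compound 4 is a 500-fold higher number from compound 3 to compound 4 (2.70 log units; beyond the scatter). Compound 4 is therefore estimated at 40000 nM, with a likely range from 8000 nM to 200000 nM.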

Compound 4, concentration for 50% growth inhibition: 52300 nM
Beside the measured number, compound 4's estimate is 1.3-fold (0.12 log units) below it, and the stated range covers the measured number.
By their numbers in this assay, from the lowest: compound 3; then compound 1; then compound 4. At a limit, above all of these: compound 2.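

In this assay the pentyl group gives a very large step (a 650-fold higher number from compound 3 to compound 4 (2.82 log units; beyond the scatter)), yet lengthening the methyl on the selenium to pentyl gives only a modest one (butyl in place of hydrogen on a saturated chain carbon bound to a selenium atom: a 2.2-fold higher number from compound 1 to compound 4 (0.35 log units; beyond the scatter)). Across compound 1, compound 3 and compound 4, most of the rise therefore goes with replacing the hydrogen on the selenium by any alkyl group, and far less with the length of that group. The remaining step (one nitrogen atom in place of a group of 6 heavy atoms: an at least 1.9-fold lower number from compound 2 to compound 4 (0.28 log units; that floor lies within the scatter)) starts from a limit of the assay, not a number, so it fixes no size for that change.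

The compounds shown leave open how the number moves with an ethyl or propyl group on the selenium. They also leave open what a chain longer than pentyl or a benzyl group would do there.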